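Amide aryl variation on the shared core: compound 4

A few compounds are considered here, and "the series" means these few. Any claim that something is new, unique, unknown or untested is made for them only; others in the source may bear on it.

Measured so far:
compound 1 `CN(C)C(=O)c1cc2cnc(Nc3ccc(NC(=O)C4(C(=O)Nc5ccccc5F)CC4)cc3)nc2n1C1CCCC1` — 79.1%
compound 2 `CN(C)C(=O)c1cc2cnc(Nc3ccc(NC(=O)C4(C(=O)Nc5ccc(Br)cc5)CC4)cc3)nc2n1C1CCCC1` — -6.6%
compound 3 `CN(C)C(=O)c1cc2cnc(Nc3ccc(NC(=O)C4(C(=O)Nc5ccc(Cl)c(C(F)(F)F)c5)CC4)cc3)nc2n1C1CCCC1` — 1.1%

In a functional assay on A549 cells (Homo sapiens) for inhibition, read by CCK-8 assay, with a stated time of 72 h, tested at 1 uM (on this read-out lower numbers stand for less inhibition of growth and higher numbers for more inhibition of growth at the one concentration tested), compound 1 stands highest of the three numbers; compound 3 is nearest to it and compound 2 furthest. Both steps away from compound 1 are large and beyond the scatter: a number 85.7 percentage points lower from compound 1 to compound 2 (beyond the scatter) and a number 78 percentage points lower from compound 1 to compound 3 (beyond the scatter). Between the two weaker compounds the step of a number 7.7 percentage points higher from compound 2 to compound 3 (within the scatter) lies within the scatter, so compound 2 and compound 3 are not distinguished by these numbers.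

Compound 4 `Cc1cccc(NC(=O)C2(C(=O)Nc3ccc(Nc4ncc5cc(C(=O)N(C)C)n(C6CCCC6)c5n4)cc3)CC2)c1` differs from compound 1 in the group on the amide-type nitrogen: 3-methylphenyl in place of 2-fluorophenyl on an amide-type nitrogen. Among the measured compounds shown here, no measured pair carries the 3-methylphenyl ring, so nothing bears on it directly. What does bear on it is that both measured replacements of the 2-fluorophenyl ring dropped the read-out sharply, with two of two exchanges ending near zero. For the measured compounds named here, compound 1 is the only compound with a high number, and its ring is the one leaving. Going by these compounds, a downward step is therefore expected for compound 4, of the size a number 44.1 percentage points lower from compound 1 to compound 4 (beyond the scatter), though with wide uncertainty since the entering ring is untested. Compound 4 is estimated at 35%, with a range of -5% to 80%.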

Compound 4, percent growth inhibition at one concentration: 35.2%
Compound 4: the middle estimate sits 0.2 percentage points below what was measured, within the range that was stated.
By their numbers in this assay, from the lowest: compounds 2 and 3 (each within the scatter of the next); then compound 4; then compound 1.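

In this assay the group on the amide-type nitrogen no longer sorts into one high number and a pair near zero, since 3-methylphenyl gives a level of its own. Taking 2-fluorophenyl away still costs much, with a number 43.9 percentage points lower from compound 1 to compound 4 (beyond the scatter) as the step, yet the 3-methylphenyl ring stands clear of both weak rings, with a number 34.1 percentage points higher from compound 3 to compound 4 (beyond the scatter) as one step and a number 41.8 percentage points higher from compound 2 to compound 4 (beyond the scatter) as the other, so loss of the 2-fluorophenyl ring does not by itself take the read-out to near zero. The leaving and entering rings match in heavy atoms and in hydrogen-bond donors and acceptors, so a large step arises here with those counts unchanged.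

Open, going by these compounds, is whether the number of compound 1 goes with the fluorine itself or with the ring as a whole, and whether a methoxy group, an amine or a carboxylic acid on this ring would keep any of the growth inhibition. Nothing at hand accounts for the order of these four rings.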